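The source may report more compounds than this note shows. Statements on the series, on what has been measured and on what is new or still open speak of the compounds shown alone.

Working notes on the series.

Compound 1 `OC[C@H]1O[C@@H](n2cnc3c(SCCCc4ccccc4)ncnc32)[C@H](O)[C@@H]1O` is the reference point. In an assay on isolated protein for binding affinity to Equilibrative nucleoside transporter 1 (Homo sapiens) (a lower number here means a stronger inhibitor, a higher number a weaker inhibitor), compound 1 gives 1350 nM. Compound 2 `CCC(C)Sc1nc(N)nc2c1ncn2[C@@H]1O[C@H](CO)[C@@H](O)[C@H]1O` carries a sec-butyl on the sulfur and a free amino group on the shared core. In this assay, among the measured compounds shown here, compound 2 gives 63100 nM, the highest of the two numbers measured so far; compound 1 sits far lower, and that gap lies well beyond the scatter of repeat measurements. Compound 3 `Nc1nc(SI)c2ncn([C@@H]3O[C@H](CO)[C@@H](O)[C@H]3O)c2n1` is the next member: it differs from compound 2 by iodo in place of sec-butyl on a sulfur. For the measured compounds named here, no measured pair shows this particular change, so its effect has to be estimated from the position of compound 2 alone. The sec-butyl of compound 2 already leaves it at the weak end of the series; swapping it for a single iodine on the sulfur gives no reason to expect a gain, and a small shift toward a weaker number, or none beyond the scatter, is the expectation, with a 1.6-fold higher number from compound 2 to compound 3 (0.20 log units; within the scatter) as the estimated step. For compound 3 the expected value in this assay is 100000 nM, within the range 20000 nM to 500000 nM.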

Compound 3, half-maximal inhibitory concentration: 81300 nM
For compound 3 the middle estimate is 1.2-fold (0.09 log units) above the measured one; low and high end bracket the measured number.
By their numbers in this assay, from the lowest: compound 1; then compounds 2 and 3 (each within the scatter of the next).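

With iodo in place of sec-butyl on a sulfur whose other neighbour is an aromatic carbon, the first step read at this position is a 1.3-fold higher number from compound 2 to compound 3 (0.11 log units; within the scatter) in this assay, so on the amino-bearing core the two groups are not told apart by this read-out. Among the compounds shown here, the branched carbon group and the single iodine therefore give values in the same weak range, and this one pair shows no dependence of the number on which of the two sits on the sulfur. No measurement bears on why the pair behaves this way, so the step stands as an observation only.

As far as these compounds go, whether this insensitivity holds for other groups on the sulfur of the amino-bearing core remains open, for example a benzyl group, a longer straight chain or a carboxylic acid at the end of such a chain. Compound 1 differs from compound 2 and from compound 3 in more than one place, so the shares of the free amino group and of the group on the sulfur in its much lower number cannot be separated from these compounds.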